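The compounds below may be only part of what the source reports. "The series", "measured", "known", "first", "only" and "open" are said of these compounds alone.

Measured compounds:
Compound 1 `COc1cccc(C(=O)Nc2ccc(Cl)cc2CN2C(=O)c3ccccc3C2=O)c1` — in an assay on CHO cells for positive allosteric modulation of metabotropic glutamate receptor 5 (Rattus norvegicus), read by FLIPR (on this read-out higher numbers stand for an effect only at larger amounts of compound and lower numbers for an effect already at smaller amounts), compound 1 gives < 1000 nM, which is a limit of the assay, not a number.
Compound 2 `O=C(Nc1ccc(Cl)cc1CN1C(=O)c2ccccc2C1=O)c1ncccn1` — in this assay compound 2 gives < 1000 nM, likewise a limit of the assay.

Compound 1 therefore stands only at a limit in this assay; nothing more exact about its position is known. Among the measured compounds shown here, the one recorded step, a step that the two limits leave unreadable from compound 1 to compound 2, is left unreadable by the two limits, and the evidence amounts to the limit of < 1000 nM in this assay, at which 2 of the 2 values shown sit. For the measured compounds named here, no step with a readable size bears on the group attached to the carbonyl carbon.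

Compound 3 `O=C(Nc1ccc(Cl)cc1CN1C(=O)c2ccccc2C1=O)c1cncs1` is not yet measured. It differs from compound 1 by 1,3-thiazol-5-yl in place of 3-methoxyphenyl on a carbonyl carbon. Going by the values given here, the only comparison of the same kind, the step from compound 1 to compound 2, cannot be read for size or direction, so the step in this assay is expected to be without readable direction and to stay near the limit region that compound 1 and compound 2 share. The expected step is a step that the limit leaves unreadable from compound 1 to compound 3. For compound 3 the estimate in this assay is 300 nM, with a range from 50 nM to 1500 nM.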

Compound 3, half-maximal effective concentration: < 1000 nM
Compound 3 was reported as a limit; the forecaster's own chance of this, stated with the estimate: 50%; the middle value does not contradict the limit.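

No new step can be read from compound 3: its steps from compound 1 and from compound 2 both stay without size or direction, since all values shown are limits: the limit of < 1000 nM in this assay, at which 3 of the 3 values shown sit.

The compounds shown leave open where compound 1, compound 2 and compound 3 truly stand in this assay, and whether the group on the carbonyl carbon changes the result at all.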